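The source may hold more compounds than are shown below. What is called first, only, known or untested is meant among the compounds shown, and "the series" means these compounds.

Compound 1 `O=C(Nc1cccc(-n2cc(-c3ccncc3)c(-c3ccc(Cl)c(O)c3)n2)c1)Nc1cccc(C(F)(F)F)c1` gives 20000 nM in a functional assay on SR cells (Homo sapiens) for inhibition, read by sulforhodamine B assay, with a stated time of 48 h; a lower number here means a stronger inhibitor of growth, a higher number a weaker inhibitor of growth.
Compound 2 `COc1cc(-c2nn(-c3cccc(NC(=O)Nc4cccc(C(F)(F)F)c4)c3)cc2-c2ccncc2)ccc1Cl` gives 2840 nM.
Compound 3 `O=C(Nc1cccc(-n2cc(-c3ccncc3)c(-c3ccc(Cl)c(O)c3)n2)c1)Nc1cc(C(F)(F)F)cc(C(F)(F)F)c1` gives 3660 nM.

Of these three measured compounds, compound 1 has the highest number in this assay, and both of its steps to the other two lie beyond the scatter, so compound 1 is the weakest growth inhibitor of the set: its nearest neighbour is compound 3 and its furthest is compound 2.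

Compound 4 `O=C(Nc1cccc(-n2cc(-c3ccncc3)c(-c3ccc(Cl)c(O)c3)n2)c1)Nc1ccc(Cl)c(C(F)(F)F)c1` has not yet been measured. It differs from compound 1 in one place: chloro in place of hydrogen on an aromatic carbon. Two measured steps start from compound 1 and bear on this change. The step of a 7.0-fold lower number from compound 1 to compound 2 (0.85 log units; beyond the scatter) alters a different part of the molecule, so it speaks only in general terms. The step of a 5.5-fold lower number from compound 1 to compound 3 (0.74 log units; beyond the scatter) is the closer guide, since that change, too, adds a new substituent where compound 1 has only hydrogen, and it lowered the number modestly. A modest lowering of the same kind is therefore expected here, with no strong reason to expect a larger or smaller one. Compound 4 is accordingly expected to show a 4.0-fold lower number from compound 1 to compound 4 (0.60 log units; beyond the scatter), giving an estimated 5000 nM, most likely between 1500 nM and 15000 nM.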

Compound 4, concentration for total growth inhibition: 2520 nM
Estimate against measurement, compound 4: 2.0-fold (0.30 log units) above, and the stated range covers the measured number.
By their numbers in this assay, from the lowest: compounds 4, 2 and 3 (each within the scatter of the next); then compound 1.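

In this assay, one chloro placed on the 3-(trifluoromethyl)phenyl ring, ortho to a trifluoromethyl group and para to a large group, gives a 7.9-fold lower number from compound 1 to compound 4 (0.90 log units; beyond the scatter), so this position takes a new atom and the number falls beyond the scatter. Alongside a 5.5-fold lower number from compound 1 to compound 3 (0.74 log units; beyond the scatter), this makes two different additions to the same ring of compound 1 that both lower the number, so among the compounds shown the gain is not tied to a single added group, although two examples are too few to make a rule. Nothing measured here explains why a chloro at this position has this effect.

The compounds shown leave open whether the chloro itself matters or whether another group at this same position, such as fluoro, methyl, an amine or a carboxylic acid, would lower the number as well. They also leave open whether this chloro would lower the number further on the core of compound 2, which carries a methyl on the oxygen where compound 1 has a hydrogen.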